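Double-bond geometry and growth inhibition in compound 4

This account rests on a few compounds, and the source may have more. Where it says the series, first, only, none or still open, it means among the compounds named here.

Of the compounds shown here, three have been measured in a functional assay on SK-MEL-5 cells (Homo sapiens) for antiproliferative activity; a higher number here means a weaker inhibitor of growth, a lower number a stronger inhibitor of growth. Compound 1 (`COCCCCCCCCCCCCCCC/C=C1/CC(CO)(COC(=O)C(C)(C)C)OC1=O`) gives 2.13 ug/mL, and compound 3 (`CC(=O)OCCCCCCCCCCCCCCC/C=C1\CC(CO)(COC(=O)C(C)(C)C)OC1=O`) gives 5.62 ug/mL. Compound 2 (`CC(C)(C)C(=O)OCC1(CO)C/C(=C\CCCCCCCCCCCCCCC=O)C(=O)O1`) reads > 10 ug/mL, which is a limit of the assay and not a number. That reading is the limit of > 10 ug/mL in this assay, at which 1 of the 3 values shown sits, so compound 2 has no exact starting value.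

Compound 4 (`CC(C)(C)C(=O)OCC1(CO)C/C(=C/CCCCCCCCCCCCCCC=O)C(=O)O1`) departs from compound 2 in geometry alone: the two compounds have the same atoms and bonds; at least one stereo element is drawn with a configuration in one of them and without one in the other: 1 of 2 stereo elements differ; a double bond is drawn E in compound 2 and Z in compound 4. Among the measured compounds shown here, the only measured step is an at least 1.7-fold lower number from compound 2 to compound 3 (0.25 log units; that floor lies within the scatter). That step leaves the double-bond geometry unchanged, so it gives no direct measure of the change in compound 4. For the measured compounds named here, with no measured step to size the change, no shift beyond the scatter can be forecast in this assay, and the direction remains open. The estimated step is an at least 1.2-fold lower number from compound 2 to compound 4 (0.09 log units; that floor lies within the scatter). For compound 4, the expected value is 8 ug/mL, with an estimated range from 3 ug/mL to 20 ug/mL.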

Compound 4, concentration for 50% growth inhibition: > 10 ug/mL
Compound 4: a limit, no number; the forecaster's own chance of this, stated with the estimate: 45%; middle value at least 1.2-fold (0.09 log units) away from the limit.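

In this assay compound 4 gives > 10 ug/mL, which is a limit of the assay and not a number. Formyl in place of methoxymethyl on a saturated chain carbon gives an at least 4.6-fold higher number from compound 1 to compound 4 (0.67 log units; beyond the scatter), the first step at this position that lies beyond the scatter. The step between the two double-bond geometries cannot be read, because compound 2 and compound 4 both stand at the same limit: the limit of > 10 ug/mL in this assay, at which 2 of the 4 values shown sit.

From the compounds shown here alone, whether the geometry of the double bond matters at all in this assay stays open, and the way the pair is drawn adds a further doubt: the fact that one of compounds 2 and 4 is drawn with a defined configuration and the other without, at the place where they differ Also open is how a carboxylic acid or an amine in place of the formyl would read in this assay.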